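Aryl ether variation on the diaminotriazine spiro core

A few compounds are considered here, and "the series" means these few. Any claim that something is new, unique, unknown or untested is made for them only; others in the source may bear on it.

Measured compounds:
compound 1, `NC1=NC2(CCOCC2)N(OCCCOc2ccccc2)C(N)=N1`: 86.1 nM
compound 2, `COc1ccc(OCCCON2C(N)=NC(N)=NC23CCOCC3)cc1`: 11.1 nM
compound 3, `NC1=NC2(CCOCC2)N(OCCCOc2ccc(Cl)cc2Cl)C(N)=N1`: 7.46 nM

All three share one core and differ only in the aryl group on the ether oxygen. In an assay on isolated protein for inhibition of Dihydrofolate reductase (Homo sapiens), read by spectrophotometry, using NADPH, with stated times of 5 s and 6 min (on this read-out higher numbers stand for weaker inhibition and lower numbers for stronger inhibition), compound 1 gives 86.1 nM, compound 2 gives 11.1 nM, and compound 3 gives 7.46 nM. Compound 3 holds the lowest number of the three, but its step from compound 2 is a 1.5-fold lower number from compound 2 to compound 3 (0.17 log units; within the scatter), so the two cannot be ordered; against compound 1 the step is a 12-fold lower number from compound 1 to compound 3 (1.06 log units; beyond the scatter).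

Compound 4, `Cc1ccc(OCCCON2C(N)=NC(N)=NC23CCOCC3)cc1`, has not yet been run in this assay. Its difference from compound 3 is 4-methylphenyl in place of 2,4-dichlorophenyl on an oxygen on a saturated carbon. For the measured compounds named here, two measured steps bear on it: a 7.8-fold lower number from compound 1 to compound 2 (0.89 log units; beyond the scatter) shows that a single group on the phenyl ring moves the number by a modest amount, and a 1.5-fold lower number from compound 2 to compound 3 (0.17 log units; within the scatter) shows that 4-methoxyphenyl and 2,4-dichlorophenyl sit within the scatter of each other. A 4-methylphenyl ring is therefore expected to land close to compound 2 and compound 3, with at most a small rise in the number. For compound 4 the estimated value in this assay is 13 nM, in the range 5 nM to 35 nM, which is expected to mean a step of a 1.7-fold higher number from compound 3 to compound 4 (0.24 log units; within the scatter).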

Compound 4, half-maximal inhibitory concentration: 56.8 nM
Compound 4: middle estimate off by 4.4-fold (0.64 log units), on the low side; the measured number lies above the stated range.
By their numbers in this assay, from the lowest: compounds 3 and 2 (each within the scatter of the next); then compounds 4 and 1 (each within the scatter of the next).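

In this assay the identity of the group on the aromatic carbon matters, and not merely its presence: methyl in place of methoxy gives a 5.1-fold higher number from compound 2 to compound 4 (0.71 log units; beyond the scatter), and the change from the 2,4-dichlorophenyl ring to the 4-methylphenyl ring gives a 7.6-fold higher number from compound 3 to compound 4 (0.88 log units; beyond the scatter). Methyl in place of hydrogen gives a 1.5-fold lower number from compound 1 to compound 4 (0.18 log units; within the scatter), so compound 1 and compound 4 cannot be ordered, and filling that aromatic carbon does not by itself carry the lower numbers of compound 2 and compound 3. No available evidence explains why methyl and methoxy part here.

Going by these compounds, whether the two chlorines of compound 3 act together or one alone suffices remains open, and a ring with a single chlorine would address this. Also open, on these data alone, is whether ethoxy or a hydroxyl group on the ring would track methoxy or methyl.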